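Compound 3 to compound 4: propanoyl on the oxygen

A few compounds are considered here, and "the series" means these few. Any claim that something is new, unique, unknown or untested is made for them only; others in the source may bear on it.

In a functional assay on K562 cells (Homo sapiens) for cytotoxicity, read by MTT assay (on this read-out higher numbers stand for weaker inhibition and lower numbers for stronger inhibition), compound 1 `COc1ccc(/C=C/C(=O)c2ccc(OC)c3c2OC(C)(C)C=C3)cc1O`, with hydrogen on the oxygen in question, gives 630 nM, compound 2 `COc1ccc(/C=C/C(=O)c2ccc(OC)c3c2OC(C)(C)C=C3)cc1OCCO` gives 8750 nM, and compound 3 `COc1ccc(/C=C/C(=O)c2ccc(OC)c3c2OC(C)(C)C=C3)cc1OCCCN(C)C` gives 2920 nM, the second highest of the three numbers. Compound 4 `CCC(=O)Oc1cc(/C=C/C(=O)c2ccc(OC)c3c2OC(C)(C)C=C3)ccc1OC` has propanoyl in place of 3-(dimethylamino)propyl on an oxygen on an aromatic ring. Both measured replacements of that hydrogen raised the number, a 14-fold higher number from compound 1 to compound 2 (1.14 log units; beyond the scatter) and a 4.6-fold higher number from compound 1 to compound 3 (0.67 log units; beyond the scatter), and the chains themselves differ, a 3.0-fold lower number from compound 2 to compound 3 (0.48 log units; beyond the scatter). Among the measured compounds shown here, no measured compound carries propanoyl there, so the expectation is loose. In this assay a modest step toward lower numbers is expected: a 2.4-fold lower number from compound 3 to compound 4 (0.39 log units; beyond the scatter). For compound 4 the estimated value is 1200 nM, with an expected range of 400 nM to 4000 nM.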

Compound 4, half-maximal inhibitory concentration: 160 nM
Compound 4: the middle estimate sits 7.5-fold (0.88 log units) above what was measured; the whole stated range lies above it.
By their numbers in this assay, from the lowest: compound 4; then compound 1; then compound 3; then compound 2.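

In this assay a group on this oxygen need not raise the number: propanoyl lowers it (a 3.9-fold lower number from compound 1 to compound 4 (0.60 log units; beyond the scatter)) where 2-hydroxyethyl and 3-(dimethylamino)propyl both raised it. The identity of the entering group therefore counts for much at this place, with propanoyl far lower than either chain (an 18-fold lower number from compound 3 to compound 4 (1.26 log units; beyond the scatter); a 55-fold lower number from compound 2 to compound 4 (1.74 log units; beyond the scatter)). No available measurement accounts for these steps.

Open, from the compounds shown here alone, is whether the lower number belongs to propanoyl alone or extends to acetyl, butanoyl or benzoyl on this oxygen. Also open, going by these compounds, is where a plain ethyl group on the same oxygen would fall.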